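Methoxy to trifluoromethoxy on the hydrazone-bearing aryl group

The compounds below may be only part of what the source reports. "The series", "measured", "known", "first", "only" and "open" are said of these compounds alone.

Three measured compounds share one core and differ only in the group on the aromatic carbon. Compound 1 `Cn1c(=O)c(=O)n(C2CCCC2)c2nc(N/N=C/c3ccc(S(C)(=O)=O)cc3)ncc21` gives 26600 nM in a functional assay on PC-3 cells (Homo sapiens) for antiproliferative activity, read by MTT assay; a lower number here means a stronger inhibitor, a higher number a weaker inhibitor. Compound 2 `Cn1c(=O)c(=O)n(C2CCCC2)c2nc(N/N=C/c3ccc(C(F)(F)F)cc3)ncc21` gives 23600 nM in this assay, and compound 3 `COc1ccc(/C=N/Nc2ncc3c(n2)n(C2CCCC2)c(=O)c(=O)n3C)cc1` gives 26300 nM in this assay. The steps among them are small: a 1.1-fold lower number from compound 1 to compound 2 (0.05 log units; within the scatter), a 1.0-fold lower number from compound 1 to compound 3 (0.00 log units; within the scatter) and a 1.1-fold higher number from compound 2 to compound 3 (0.05 log units; within the scatter), each within the scatter. Compound 3 thus stands as the second highest of the three numbers, with compound 1 nearest and compound 2 furthest, both gaps within the scatter, so no order among the three can be claimed.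

Compound 4 `Cn1c(=O)c(=O)n(C2CCCC2)c2nc(N/N=C/c3ccc(OC(F)(F)F)cc3)ncc21` differs from compound 3 by trifluoromethyl in place of methyl on an oxygen on an aromatic ring. Among the measured compounds shown here, the steps that bear on this change are the three exchanges at the same aromatic carbon, a 1.0-fold lower number from compound 1 to compound 3 (0.00 log units; within the scatter), a 1.1-fold higher number from compound 2 to compound 3 (0.05 log units; within the scatter) and a 1.1-fold lower number from compound 1 to compound 2 (0.05 log units; within the scatter), all within the scatter. Since no exchange at this position has moved the number, the expectation for compound 4 in this assay is no step beyond the scatter, with a 1.1-fold lower number from compound 3 to compound 4 (0.02 log units; within the scatter) expected. Compound 4 is therefore estimated at 25000 nM, with a range from 12000 nM to 55000 nM.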

Compound 4, half-maximal inhibitory concentration: 7180 nM
Compound 4: the middle estimate sits 3.5-fold (0.54 log units) above what was measured, outside the stated range (below it).
By their numbers in this assay, from the lowest: compound 4; then compounds 2, 3 and 1 (each within the scatter of the next).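

In this assay this aromatic carbon now shows a response to substitution, since trifluoromethyl in place of methyl on the oxygen gives a step beyond the scatter (a 3.7-fold lower number from compound 3 to compound 4 (0.56 log units; beyond the scatter)), whereas the exchanges among the three earlier compounds gave none. The separation holds against the other two groups as well (a 3.3-fold lower number from compound 2 to compound 4 (0.52 log units; beyond the scatter); a 3.7-fold lower number from compound 1 to compound 4 (0.57 log units; beyond the scatter)), so among these four compounds trifluoromethoxy alone stands apart, while methoxy, trifluoromethyl and methylsulfonyl remain within the scatter of one another. Neither the oxygen carrying a methyl in compound 3 nor the trifluoromethyl directly on the ring in compound 2 gives this step, only the oxygen and the trifluoromethyl together in compound 4, and no measurement at hand explains the gain.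

The compounds shown leave open whether the step is particular to trifluoromethoxy or also extends to a longer chain on the oxygen, such as ethoxy or pentafluoroethoxy, or to an amine or a carboxylic acid on this carbon. They also leave open whether the step would persist with a different group in place of the cyclopentyl on the shared core.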